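The source may report more compounds than this note shows. Statements on the series, on what has been measured and on what is new or still open speak of the compounds shown alone.

Three compounds were examined in an assay on cell membranes for displacement of a labelled ligand from Neuronal acetylcholine receptor; alpha4/beta2 (Rattus norvegicus) (a higher number here means a weaker inhibitor, a lower number a stronger inhibitor), a test in which compounds compete with a labelled molecule for binding on cell membranes. Compound 1, with the structure `COc1ccc(Nc2cncc(N3CC4CC(C3)N4)c2)cc1`, gives 0.0598 nM in this assay. Compound 2, `Clc1ccc(Nc2ccc(N3CC4CC(C3)N4)cn2)cc1`, gives 2.49 nM, and compound 3, `Clc1cccc(Nc2ccc(N3CC4CC(C3)N4)nn2)c1`, gives 1540 nM. Of the three numbers, that of compound 1 is the lowest, and its distance to each of the other two is well beyond the scatter of repeated measurements, so compound 1 is the strongest inhibitor among them.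

The unmeasured compound 4, `Fc1ccc(Nc2cncc(N3CC4CC(C3)N4)c2)cc1`, is obtained from compound 1 by a single change: fluoro in place of methoxy on an aromatic carbon. Nothing measured here shows what a swap of this kind does on this core, so the expected step from compound 1 to compound 4 rests on the structural change alone. A small step in this assay is expected, more likely toward a weaker inhibitor than a stronger one, and the step that is expected is a 2.5-fold higher number from compound 1 to compound 4 (0.40 log units; beyond the scatter). Compound 4 is therefore estimated at 0.15 nM, within a range from 0.03 nM to 0.8 nM.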

Compound 4, inhibition constant: 0.091 nM
For compound 4 the middle estimate is 1.6-fold (0.22 log units) above the measured one; the range from low to high includes it.
By their numbers in this assay, from the lowest: compounds 1 and 4 (each within the scatter of the next); then compound 2; then compound 3.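

On an aromatic carbon of the six-membered ring of carbon only, para to a large group, fluoro in place of methoxy gives a 1.5-fold higher number from compound 1 to compound 4 (0.18 log units; within the scatter) in this assay. Methoxy counts one hydrogen-bond acceptor and fluoro none, yet compound 1 and compound 4 cannot be told apart here, so on this core the acceptor of methoxy is not needed to keep the number this low. Nothing measured here gives a reason for this outcome.

Going by these compounds, whether an amine, a carboxylic acid or a longer chain such as ethoxy at this place would also stay within the scatter of compound 1 remains open. On these data alone, compound 2 and compound 3 differ from compound 1 in more than one place, so whether this swap gives a similar step on other cores also stays open.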